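Chloro for fluoro on a quinolone acid, tolerability expected unchanged

The compounds below may be only part of what the source reports. "The series", "measured", "known", "first", "only" and "open" are said of these compounds alone.

Measured compounds:
compound 1 `CCOC(=O)c1cn(COCCO)c2cc(Cl)ccc2c1=O`: 1200000 nM
compound 2 `O=C(O)c1cn(COCCO)c2cc(F)ccc2c1=O`: > 500000 nM

Of the compounds shown here, two have been measured in a functional assay on Vero cells (Chlorocebus sabaeus) for cytotoxicity, read by MTT assay; a higher number here means that more compound is tolerated, a lower number that less compound is tolerated. In this assay compound 1 gives 1200000 nM. For compound 2 in this assay only a limit is known, > 500000 nM. That is a boundary of the assay, not a number, as noted at the limit of > 500000 nM in this assay, at which 1 of the 2 values shown sits, so where compound 2 truly stands cannot be read from the data; it sits at or beyond the boundary.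

Compound 3 `O=C(O)c1cn(COCCO)c2cc(Cl)ccc2c1=O` differs from compound 2 by chloro in place of fluoro on an aromatic carbon. Within the data shown here, no measured step between two compounds is recorded here, so the size of this step in this assay is not known from any pair. No change beyond the usual scatter is expected in either direction. Compound 3 is expected to give 1000000 nM in this assay, between 400000 nM and 3000000 nM, a step that the limit leaves unreadable from compound 2 to compound 3, and it may well again come back only as a limit.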

Compound 3, half-maximal cytotoxic concentration: 1200000 nM
The estimate for compound 3 lay 1.2-fold (0.08 log units) below the measured number; low and high end bracket the measured number.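

In this assay, hydrogen in place of ethyl on an oxygen next to a carbonyl group gives no change at the digits printed from compound 1 to compound 3 (within the scatter), so with chloro on the aromatic carbon, the acid and the ethyl ester cannot be told apart. For compound 2 the only entry is > 500000 nM, which is a limit of the assay and not a number. The step of chloro in place of fluoro on the aromatic carbon therefore cannot be read, and this position remains unresolved: the limit of > 500000 nM in this assay, at which 1 of the 3 values shown sits.

Where compound 2 truly stands, and so whether fluoro and chloro differ at all, stays open. Also open, from the compounds shown here alone, is whether a bromo or an amine on that aromatic carbon, or a longer chain than ethyl on that oxygen, would move the tolerated concentration.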